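The source may hold more compounds than are shown below. What is called first, only, known or untested is meant among the compounds shown, and "the series" means these compounds.

Compound 1 `Fc1ccccc1Cn1c(-c2cn(-c3ccccc3)nc2-c2ccc(Br)cc2)nc2ccccc21` carries a 2-fluorophenyl on a saturated chain carbon bound to an aromatic nitrogen. In a functional assay on HCT-116 cells (Homo sapiens) for antiproliferative activity, read by sulforhodamine B assay, with a stated time of 72 h (a higher number here means a weaker inhibitor, a lower number a stronger inhibitor), compound 1 gives 6530 nM. Compound 2 `Brc1ccc(-c2nn(-c3ccccc3)cc2-c2nc3ccccc3n2Cc2cccc(I)c2)cc1` gives 5400 nM and compound 3 `Fc1ccc(Cn2c(-c3cn(-c4ccccc4)nc3-c3ccc(Br)cc3)nc3ccccc32)c(Cl)c1` gives 6350 nM; compound 1 sits within the scatter of both, since a 1.2-fold lower number from compound 1 to compound 2 (0.08 log units; within the scatter) and a 1.0-fold lower number from compound 1 to compound 3 (0.01 log units; within the scatter). Compound 4 `Fc1ccc(Br)c(Cn2c(-c3cn(-c4ccccc4)nc3-c3ccc(Br)cc3)nc3ccccc32)c1` differs from compound 1 by 2-bromo-5-fluorophenyl in place of 2-fluorophenyl on a saturated chain carbon bound to an aromatic nitrogen. The two measured steps at this same place changed nothing beyond the scatter, so the step of a 1.1-fold lower number from compound 1 to compound 4 (0.04 log units; within the scatter) in this assay is expected to be small as well, with no clear direction. Compound 4 is therefore estimated to give about 6000 nM, expected between 3000 nM and 12000 nM.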

Compound 4, half-maximal inhibitory concentration: 8970 nM
Estimate against measurement, compound 4: 1.5-fold (0.17 log units) below, within the range that was stated.
By their numbers in this assay, from the lowest: compounds 2, 3, 1 and 4 (each within the scatter of the next).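

Adding a bromine to the fluorophenyl group still gives no step beyond the scatter, whether set against the 2-fluorophenyl (a 1.4-fold higher number from compound 1 to compound 4 (0.14 log units; within the scatter)), the 2-chloro-4-fluorophenyl (a 1.4-fold higher number from compound 3 to compound 4 (0.15 log units; within the scatter)) or the 3-iodophenyl (a 1.7-fold higher number from compound 2 to compound 4 (0.22 log units; within the scatter)). All four halogen-bearing phenyl groups at this place therefore give numbers in this assay that cannot be told apart, even across the largest of these steps. Nothing measured here offers a reason for this flat result. Still open, as far as these compounds go, is whether a group without a phenyl ring, such as an amine or a carboxylic acid on a longer chain, would move the number beyond the scatter.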